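Ethoxy in Place of Propyl: Compound 3 to Compound 4

The compounds below may be only part of what the source reports. "The series", "measured", "known", "first", "only" and "open" are said of these compounds alone.

Within the data shown here, in a functional assay on MCF7 cells (Homo sapiens) for inhibition, read by sulforhodamine B assay (on this read-out higher numbers stand for weaker inhibition and lower numbers for stronger inhibition), compound 1 `O=C1C=C(Nc2ccc(I)cc2)C(=O)c2c1nc1n2[C@H]2OC[C@@H](O)[C@H]2OC1` gives 2230 nM and compound 2 `Cc1ccc(NC2=CC(=O)c3nc4n(c3C2=O)[C@H]2OC[C@@H](O)[C@H]2OC4)cc1` gives 1660 nM; the only measured step, a 1.3-fold lower number from compound 1 to compound 2 (0.13 log units; within the scatter), stays within the scatter. Compound 3 `CCCc1ccc(NC2=CC(=O)c3c(nc4n3[C@H]3OC[C@@H](O)[C@H]3OC4)C2=O)cc1` yields no number in this assay but only a limit, > 4000 nM, (the limit of > 4000 nM in this assay, at which 1 of the 3 values shown sits). Compound 4 `CCOc1ccc(NC2=CC(=O)c3c(nc4n3[C@H]3OC[C@@H](O)[C@H]3OC4)C2=O)cc1` differs from compound 3 by ethoxy in place of propyl on an aromatic carbon. Among the measured compounds shown here, no measured step touches this exchange, and the one step available, iodo to methyl, gives no direction, so the expected step of an at least 1.1-fold lower number from compound 3 to compound 4 (0.05 log units; that floor lies within the scatter) is set close to no change, with wide uncertainty. Compound 4 is therefore estimated at 3500 nM in this assay, with a range from 1200 nM to 9000 nM, and a real chance that only a limit is returned again.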

Compound 4, half-maximal inhibitory concentration: > 4000 nM
Compound 4: a limit, no number; the forecaster's own chance of this, stated with the estimate: 40%; middle value at least 1.1-fold (0.05 log units) away from the limit.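

No step can be read from compound 3 to compound 4, because each returns only a limit in this assay: the limit of > 4000 nM in this assay, at which 2 of the 4 values shown sit.

On these data alone, whether ethoxy in place of propyl shifts inhibition at all, and in which direction, stays open.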